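The compounds below may be only part of what the source reports. "The series", "measured", "known", "first", "only" and "open" are said of these compounds alone.

Measured so far:
compound 1, `CCCCc1ccc(NC(=O)N[C@@H](C)c2ccccc2)cc1`: 98%
compound 2, `CCCCCc1ccc(NC(=O)N[C@@H](C)c2ccccc2)cc1`: 98%

In an ADME assay on the whole organism with Oryza sativa as the target, tested at 0.1 uM (on this read-out lower numbers stand for a stronger effect and higher numbers for a weaker effect at the one concentration tested), compound 1 gives 98%. Compound 2 `CCCCCc1ccc(NC(=O)N[C@@H](C)c2ccccc2)cc1` stands level with it: in this assay compound 2 gives 98%, and the step of no change at the digits printed from compound 1 to compound 2 (within the scatter) lies within the scatter. Compound 2 is thus at the same level as its only neighbour on the numbers shown.

Compound 3 `CCCCCCc1ccc(NC(=O)N[C@@H](C)c2ccccc2)cc1` is not yet measured in this assay. Its difference from compound 2 is methyl in place of hydrogen on a saturated chain carbon, five bonds along the chain from an aromatic carbon. Among the compounds with values here, the one measured step of the same kind, no change at the digits printed from compound 1 to compound 2 (within the scatter), produced no change beyond the scatter, and it is the only step that bears on this change. On that basis no step beyond the scatter is expected for compound 3 in this assay; the expected step is a number 1 percentage points lower from compound 2 to compound 3 (within the scatter). The estimate for compound 3 in this assay is therefore 97%, expected to fall between 88% and 100%.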

Compound 3, a percentage reported as activity, at one concentration (the size of the read-out at that concentration, not a potency): 99%
Compound 3: middle estimate off by 2 percentage points, on the low side; low and high end bracket the measured number.
By their numbers in this assay, from the lowest: compounds 1, 2 and 3 (each within the scatter of the next).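

In this assay, methyl in place of hydrogen on a saturated chain carbon, five bonds along the chain from an aromatic carbon, gives a number 1 percentage points higher from compound 2 to compound 3 (within the scatter), so the flat reading seen four bonds along the chain also holds one bond further out. Taken across both steps, the whole change in the chain gives a number 1 percentage points higher from compound 1 to compound 3 (within the scatter), so the ethyl change does not separate the compounds on this read-out either. No measurement is available that could explain this level reading.

From the compounds shown here alone, compounds 1, 2 and 3 carry only plain saturated chains, so it remains open whether a longer chain, or a chain ending in an amine or a carboxylic acid, would move the number in this assay beyond the scatter. Changes elsewhere on the shared core also remain open.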